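From iodo to hydrogen at the assay limit

The source may hold more compounds than are shown below. What is called first, only, known or untested is meant among the compounds shown, and "the series" means these compounds.

In an ADME assay on cells (Erythrocyte, Homo sapiens), read by hemolysis, with a stated time of 1 h (on this read-out lower numbers stand for stronger inhibition and higher numbers for weaker inhibition), three compounds have been read so far. Compound 1 `CC(=NNC(=S)Nc1cccc(F)c1)c1ccccn1` gives > 10000 nM, which is a limit of the assay and not a number. Compound 2 `CC(=NNC(=S)Nc1cccc(I)c1)c1ccccn1` gives > 10000 nM, again only a limit. Compound 3 `CC(=NNC(=S)Nc1ccccc1[N+](=O)[O-])c1ccccn1` gives > 10000 nM, also a limit.

Compound 2 therefore has no numerical position in the series. Among the compounds with values here, the one measured step that bears on its aromatic substituent is a step that the two limits leave unreadable from compound 1 to compound 2, with iodo in place of fluoro, and it offers no size to carry forward.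

Compound 4 `CC(=NNC(=S)Nc1ccccc1)c1ccccn1` is still unmeasured. It differs from compound 2 by hydrogen in place of iodo on an aromatic carbon, with hydrogen in place of iodo on an aromatic carbon.

Within the data shown here, with the limit of > 10000 nM in this assay, at which 3 of the 3 values shown sit, as the only guide, no step beyond the scatter is expected in this assay, in either direction. The estimated step is a step that the limit leaves unreadable from compound 2 to compound 4, and another limit is the expected report. Compound 4 is estimated at 20000 nM, with an expected range of 8000 nM to 60000 nM.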

Compound 4, half-maximal inhibitory concentration: > 10000 nM
Compound 4 ended at the assay's limit; the forecaster's own chance of this, stated with the estimate: 90%; the middle value does not contradict the limit.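

No step to compound 4 can be read from compound 1, compound 2 or compound 3, because all four compounds report only a limit: the limit of > 10000 nM in this assay, at which 4 of the 4 values shown sit.

The compounds shown leave open whether any aromatic substituent here gives a readable value in this assay.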